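Amino for chloro: one measured step, carried to compound 4

The compounds below may be only part of what the source reports. "The series", "measured", "known", "first", "only" and "open" are said of these compounds alone.

Among the measured compounds shown here, compound 2 `ClCc1cccc(Cn2cnc3c(Cl)nc(Cl)nc32)c1` gives 3160 nM in a functional assay on HCC 2998 cells (Homo sapiens) for cytotoxicity, read by sulforhodamine B assay, with a stated time of 48 h (a higher number here means a weaker inhibitor of growth, a lower number a stronger inhibitor of growth), the lowest of the three numbers measured so far. Compound 1 `Nc1nc(Cl)c2ncn(Cc3ccc(CCl)cc3)c2n1` gives 8910 nM in this assay, and compound 3 `ClCc1ccc(Cn2cnc3c(Cl)nc(Cl)nc32)cc1` gives 24000 nM in this assay. Compound 2 and compound 3 are built from the same atoms joined differently; the difference between the two cores is not broken down here.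

The change from compound 3 to compound 1 is amino in place of chloro on an aromatic carbon. In this assay it produced a 2.7-fold lower number from compound 3 to compound 1 (0.43 log units; beyond the scatter).

Compound 4 `Nc1nc(Cl)c2ncn(Cc3cccc(CCl)c3)c2n1` has not yet been measured in this assay. It differs from compound 2 by amino in place of chloro on an aromatic carbon; the group leaving, the group entering and the place described are the same in every word, so this is the same change carried onto the core of compound 2.

For the measured compounds named here, a step of similar size is expected, a 2.6-fold lower number from compound 2 to compound 4 (0.42 log units; beyond the scatter), because a 2.7-fold lower number from compound 3 to compound 1 (0.43 log units; beyond the scatter) is the only precedent available and it lies beyond the usual scatter. The expected number for compound 4 is 1200 nM, with a range from 500 nM to 3200 nM.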

Compound 4, concentration for total growth inhibition: 4890 nM
The estimate for compound 4 lay 4.1-fold (0.61 log units) below the measured number; the whole stated range lies below it.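

In this assay, amino in place of chloro on an aromatic carbon gave a 1.5-fold higher number from compound 2 to compound 4 (0.19 log units; within the scatter), so on the core of compound 2 this change leaves the number inside the usual scatter. Among the compounds shown here, the same change therefore did not carry over as a constant step from one core to the other: the same change on two cores in this assay, a 2.7-fold lower number (0.43 log units; beyond the scatter) from compound 3 to compound 1 and a 1.5-fold higher number (0.19 log units; within the scatter) from compound 2 to compound 4, 4.2-fold (0.62 log units) apart, beyond the scatter of two such steps This shows that, in this series, a step read on one core is not a safe guide to the step on the other, but with only two pairs in a single assay it does not show what in the cores sets the two steps apart, nor how the change would run on any further core.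

The compounds shown leave open whether a methylamino or methoxy group in place of the same chloro group would follow amino on either core. Equally open, from the compounds shown here alone, is how a hydroxymethyl or plain methyl group in place of chloromethyl would read in this assay.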